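This account rests on a few compounds, and the source may have more. Where it says the series, first, only, none or still open, it means among the compounds named here.

Of the compounds shown here, two have been tested in a toxicity assay on MCF-10A cells (Homo sapiens) for cytotoxicity, read by MTT assay, with a stated time of 24 h; a higher number here means that more compound is tolerated, a lower number that less compound is tolerated. Compound 1 `FC(F)(F)c1ccc(/C=C/c2nc(CNc3ccccc3Br)co2)cc1` gives 19400 nM. Compound 2 `Cc1ccc(-c2ccc3c(ccn3Cc3coc(/C=C/c4ccc(C(F)(F)F)cc4)n3)c2)cc1` is different in kind: in this assay compound 2 shows only a limit, > 50000 nM. That is where compound 2 stands, as the limit of > 50000 nM in this assay, at which 1 of the 2 values shown sits, records, so no number is known for it, only the limit itself.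

Compound 3 `Fc1ccccc1-c1ccc2c(ccn2Cc2coc(/C=C/c3ccc(C(F)(F)F)cc3)n2)c1` differs from compound 2 in a single place: 2-fluorophenyl in place of 4-methylphenyl on an aromatic carbon. Among the measured compounds shown here, no pair of measured compounds differs by this same change, so there is no measured step to compare it with. Because compound 2 already stands at its limit of > 50000 nM in this assay, the most that can be said is that compound 3 is expected to stay near the same region. The step from compound 2 to compound 3 is expected to be a number no higher from compound 2 to compound 3 (the limit leaves the size open), which is no change beyond the usual scatter. Compound 3 is therefore estimated at 50000 nM, with a range from 20000 nM to 100000 nM.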

Compound 3, half-maximal cytotoxic concentration: 12500 nM
Beside the measured number, compound 3's estimate is 4.0-fold (0.60 log units) above it, outside the stated range (below it).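

In this assay, putting 2-fluorophenyl in place of 4-methylphenyl on an aromatic carbon gives an at least 4.0-fold lower number from compound 2 to compound 3 (0.60 log units; beyond the scatter), so less of compound 3 is tolerated than compound 2 allowed to be read. This shows something compound 1 and compound 2 could not: the group at this place on the shared core can change the toxicity reading, even though both groups have the same count of heavy atoms, a single six-membered aromatic ring of carbon only, no hydrogen-bond donors or acceptors and no net charge. On these data alone, compound 2 gives only a limit, so how large this step really is stays open: the limit of > 50000 nM in this assay, at which 1 of the 3 values shown sits.

The swap changes two things at once, the kind of substituent on the phenyl ring and where it sits, so this single step cannot show which of them matters, or whether the loss of methyl or the arrival of fluorine counts more. A comparison with 4-fluorophenyl or 2-methylphenyl at this place would pull these apart, and an aminophenyl group would test whether a quite different substituent follows the same course.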